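Triazole N-substituent swap toward a dimethoxyphenyl amide analogue

The source may hold more compounds than are shown below. What is called first, only, known or untested is meant among the compounds shown, and "the series" means these compounds.

Measured so far in an in vitro assay on LLC-PK1 cells for displacement of a labelled ligand from growth hormone secretagogue receptor type 1 (Homo sapiens); a higher number here means a weaker inhibitor, a lower number a stronger inhibitor:
- compound 1 `COc1ccc(-n2c(CCc3ccccc3)nnc2[C@H](NC(=O)Cc2ccccn2)c2c[nH]c3ccccc23)c(OC)c1`: 120 nM
- compound 2 `COc1ccc(Cn2c(CCc3ccccc3)nnc2[C@H](NC(=O)c2cnccn2)c2c[nH]c3ccccc23)cc1`: 14 nM
- compound 3 `CCc1ccc(Cn2c(CCc3ccccc3)nnc2[C@H](NC(=O)c2cnccn2)c2c[nH]c3ccccc23)cc1`: 89 nM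

Compound 3 stands second highest of the three numbers. Its nearest neighbour is compound 1, whose number sits within the scatter of it, while compound 2 gives a number well below, the step being a 6.4-fold higher number from compound 2 to compound 3 (0.80 log units; beyond the scatter).

Compound 4 is `COc1ccc(-n2c(CCc3ccccc3)nnc2[C@H](NC(=O)c2cnccn2)c2c[nH]c3ccccc23)c(OC)c1`. It differs from compound 3 by 2,4-dimethoxyphenyl in place of 4-ethylbenzyl on an aromatic nitrogen. Within the data shown here, no measured step bears directly on this change: the one measured step, a 6.4-fold higher number from compound 2 to compound 3 (0.80 log units; beyond the scatter), concerns only the methoxy and ethyl groups on the benzyl ring, and compound 1 carries the same 2,4-dimethoxyphenyl group as compound 4 but with a different amide, so it shows only that this group is compatible with a number near that of compound 3. Compound 2 shows that the pyrazine amide series can reach low numbers. A modest move in this assay is therefore expected, downward, amounting to a 1.8-fold lower number from compound 3 to compound 4 (0.25 log units; within the scatter). Compound 4 is estimated at 50 nM, with a range from 12 nM to 200 nM.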

Compound 4, half-maximal inhibitory concentration: 300 nM
Estimate against measurement, compound 4: 6.0-fold (0.78 log units) below, outside the stated range (above it).
By their numbers in this assay, from the lowest: compound 2; then compounds 3 and 1 (each within the scatter of the next); then compound 4.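

With the pyrazin-2-yl amide held fixed, putting 2,4-dimethoxyphenyl on the aromatic nitrogen gives a weaker inhibitor in this assay than either benzyl group does, with a 3.4-fold higher number from compound 3 to compound 4 (0.53 log units; beyond the scatter) against the 4-ethylbenzyl group and a 21-fold higher number from compound 2 to compound 4 (1.33 log units; beyond the scatter) against the 4-methoxybenzyl group. With 2,4-dimethoxyphenyl held fixed, the amide also matters: there is a 2.5-fold higher number from compound 1 to compound 4 (0.40 log units; beyond the scatter) on going to pyrazin-2-yl, so the low number of compound 2 does not carry over to this aromatic nitrogen substituent. No available evidence accounts for these shifts.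

The compounds shown leave open whether the loss follows the removal of the benzyl carbon or the arrangement of the methoxy groups, a question that a 2,4-dimethoxybenzyl or 4-methoxyphenyl group would separate. As far as these compounds go, it also remains open how the (pyridin-2-yl)methyl amide behaves with a 4-methoxybenzyl group.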